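Methyl Added to a Sulfonamide Ring: Expected Shift in Acidity

The source may report more compounds than this note shows. Statements on the series, on what has been measured and on what is new or still open speak of the compounds shown alone.

Compound 1 `O=[N+]([O-])c1cccc(NS(=O)(=O)c2ccccc2)c1` and compound 2 `Cc1ccc(S(=O)(=O)Nc2cccc([N+](=O)[O-])c2)cc1` share one core and differ in a single place: methyl in place of hydrogen on an aromatic carbon. In an ADME assay, compound 1 gives 7.93, and compound 2 gives 8.27. That single change produced a step of a number 0.34 log units higher from compound 1 to compound 2 (beyond the scatter). Compound 3 `O=S(=O)(Nc1ccc(Cl)cc1)c1ccccc1` is built on a different core, and the difference between the two cores is not broken down here. In this assay compound 3 gives 8.75, the highest of the three measured numbers. Compound 4 `Cc1ccc(S(=O)(=O)Nc2ccc(Cl)cc2)cc1` differs from compound 3 by the same change: methyl in place of hydrogen on an aromatic carbon. A step of a number 0.34 log units higher from compound 3 to compound 4 (beyond the scatter) is expected, resting on the earlier measured step of a number 0.34 log units higher from compound 1 to compound 2 (beyond the scatter). Compound 4 is therefore estimated at 9.09, most likely between 8.75 and 9.45.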

Compound 4, acid dissociation constant: 9.02
Compound 4: the middle estimate sits 0.07 log units above what was measured; low and high end bracket the measured number.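

In this assay, putting methyl in place of hydrogen on an aromatic carbon of the core of compound 3 gives a step of a number 0.27 log units higher from compound 3 to compound 4 (within the scatter). Set beside the earlier step, the change carried from one core to the other with no difference beyond the scatter: the same change on two cores in this assay, a number 0.34 log units higher (beyond the scatter) from compound 1 to compound 2 and a number 0.27 log units higher (within the scatter) from compound 3 to compound 4, 0.07 log units apart, within the scatter of two such steps This rests on just two cores, and the second step taken alone cannot be told apart from the scatter, so it does not show that the same step would appear on every core in this series.

The compounds shown leave open whether another group in the same place, such as an amine, a carboxylic acid or a longer chain, would carry over as consistently. They also leave open how methyl would behave elsewhere on the ring.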